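Cyclopropyl for Difluorophenyl on a Shared Amide Core

The compounds below may be only part of what the source reports. "The series", "measured", "known", "first", "only" and "open" are said of these compounds alone.

Two compounds share an amide core and differ at two positions. Compound 1 `Cc1cc(NC(=O)Cn2nnc(-c3ccccc3)n2)n(-c2ccccc2)n1` gives 66% in an assay on HEK293 cells for activation of Kir3.1/Kir3.2 (Homo sapiens), read by thallium flux; on this read-out lower numbers stand for smaller maximal responses and higher numbers for larger maximal responses. Compound 2 `Cc1cc(NC(=O)Cn2nnc(-c3ccc(F)c(F)c3)n2)n(C2CCCCC2)n1` gives 93% in this assay, the highest of the two numbers; its nearest neighbour is compound 1, a number lower by a gap beyond the usual scatter. For the measured compounds named here, no pair that differs in a single place has been measured, so no single step is known here.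

Compound 3 `Cc1cc(NC(=O)Cn2nnc(C3CC3)n2)n(C2CCCCC2)n1` is not yet measured. It differs from compound 2 as follows: cyclopropyl in place of 3,4-difluorophenyl on an aromatic carbon. Without any measured step of this kind, the expected change cannot be anchored to data; a modest drop in this assay is expected, and a result within the scatter would not be surprising. The step from compound 2 to compound 3 is thus expected to be a number 13 percentage points lower from compound 2 to compound 3 (beyond the scatter). For compound 3 the estimate in this assay is 80%, with a range from 55% to 100%.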

Compound 3, largest response reached (Emax), in percent of the reference or control that the assay uses: > 68%
Compound 3: no number, only a limit (the forecaster's own chance of this, stated with the estimate: 0%); the middle value lies beyond the limit too.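

In this assay, for the compounds shown here, compound 3 gives > 68%, which is a limit and not a number, so no step from compound 2 to compound 3 can be read. The compounds shown leave open how far cyclopropyl in place of 3,4-difluorophenyl changes the maximal response.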